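The compounds below may be only part of what the source reports. "The series", "measured", "known", "first", "only" and "open" are said of these compounds alone.

Measured so far in this series:

compound 1, `CNC(=O)c1c(O)c2cccnc2n(-c2ccccc2)c1=O` — 21%
compound 2, `O=C(Nc1cccnc1)c1c(O)c2cccnc2n(-c2ccccc2)c1=O` — 30.8%

In a functional assay on the whole organism for inhibition, with Rattus norvegicus as the target, read by cytopathic effect and paw edema, at a dose of 100 mg/kg by the oral route (a higher number here means more inhibition at the dose given (going by the name of the read-out), a lower number less inhibition), compound 2 gives 30.8%, the higher of the two numbers available. Among the measured compounds shown here, the nearest number is that of compound 1, and the single measured step, a number 9.8 percentage points higher from compound 1 to compound 2 (within the scatter), lies within the scatter, so no order between these two compounds can be claimed.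

Compound 3, `O=C(Nc1ccc(Cl)nc1)c1c(O)c2cccnc2n(-c2ccccc2)c1=O`, is not yet measured. It differs from compound 2 in one place: chloro in place of hydrogen on an aromatic carbon, read one bond further out as pyridin-3-yl to 6-chloropyridin-3-yl. For the measured compounds named here, no measured step bears on this change: the only step in hand, a number 9.8 percentage points higher from compound 1 to compound 2 (within the scatter), concerns the group on the amide-type nitrogen, not a substituent on the six-membered aromatic ring with 1 nitrogen. There is therefore nothing in the data to support a step beyond the scatter in either direction in this assay.

On that basis compound 3 is expected to give about 32%, with a range of 15% to 50%. The expected step is a number 1.2 percentage points higher from compound 2 to compound 3 (within the scatter), which is taken to be within the scatter.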

Compound 3, a percentage reported as inhibition, in the whole organism at one dose (the size of the read-out at that dose, not a potency): -4%
Compound 3: the middle estimate sits 36 percentage points above what was measured; measured number outside the range, below it.
By their numbers in this assay, from the lowest: compound 3; then compounds 1 and 2 (each within the scatter of the next).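

In this assay the ring of the amide substituent proves to be a sensitive place: a single chlorine atom on the aromatic carbon next to the ring nitrogen, para to a large group, gives a number 34.8 percentage points lower from compound 2 to compound 3 (beyond the scatter) and so moves the number beyond the scatter, which the earlier exchange of methyl for pyridin-3-yl on the amide-type nitrogen did not do. The same holds against the methyl amide, with a number 25 percentage points lower from compound 1 to compound 3 (beyond the scatter) for 6-chloropyridin-3-yl in place of methyl, so among these compounds the low number comes only with the chloro-bearing ring, while the plain pyridin-3-yl of compound 2 stays within the scatter of the methyl of compound 1. Nothing available explains why this one atom has so large an effect on the read-out in the whole animal.

Open, from the compounds shown here alone, is whether the loss belongs to chloro itself or to any substituent on this carbon, which a fluoro, a methyl, a methoxy or an amino group in the same place would help to separate. Also open, going by these compounds, is whether chloro elsewhere on the ring, or on the phenyl group of the shared core, would give the same fall at this single oral dose.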